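Losing one anilino group from compound 1

A few compounds are considered here, and "the series" means these few. Any claim that something is new, unique, unknown or untested is made for them only; others in the source may bear on it.

Values in a functional assay on KG-1 cells (Homo sapiens) for inhibition, read by MTT assay, with a stated time of 48 h; on this read-out higher numbers stand for weaker inhibition and lower numbers for stronger inhibition:
Compound 1 `O=C(CCCCNC(=O)Cn1cnc2c(Nc3ccccc3)nc(Nc3ccccc3)nc21)NO`: 34700 nM
Compound 2 `O=C(CCCCCNC(=O)Cn1cnc2c(Nc3ccccc3)nc(Nc3ccccc3)nc21)NO`: 3800 nM

Compound 1 has the higher of these two numbers, which makes it the weaker inhibitor of the pair in this assay. Among the compounds with values here, the only measured step, a 9.1-fold lower number from compound 1 to compound 2 (0.96 log units; beyond the scatter), alters the chain that ends in the hydroxycarbamoyl group and leaves the shared core unchanged. Compound 3 `O=C(CCCCNC(=O)Cn1cnc2c(Nc3ccccc3)ncnc21)NO` keeps the chain of compound 1 and alters the core instead: hydrogen in place of anilino on an aromatic carbon. Within the data shown here, no measured step touches this place, so the chain step shows only how far a single change has moved the number here. A small step toward a higher number is expected, perhaps not beyond the scatter. The expected step is a 1.4-fold higher number from compound 1 to compound 3 (0.16 log units; within the scatter). For compound 3 the estimated value is 50000 nM, with an expected range of 15000 nM to 150000 nM.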

Compound 3, half-maximal inhibitory concentration: > 50000 nM
Compound 3: only a limit was reported; the forecaster's own chance of this, stated with the estimate: 20%; the middle value lies on the limit itself.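

In this assay, within the data shown here, compound 3 gives only a limit of the assay, > 50000 nM, and this is the first reading of a change to the shared core rather than to the chain. Hydrogen in place of anilino on this aromatic carbon gives an at least 1.4-fold higher number from compound 1 to compound 3 (0.15 log units; that floor lies within the scatter), so the change shows no sign of lowering the number, though the floor alone does not separate the two compounds. How much the anilino group counts here cannot be read, because the reading stops at a ceiling: the limit of > 50000 nM in this assay, at which 1 of the 3 values shown sits.

The compounds shown leave open whether a smaller group at this aromatic carbon, such as an amine or a methoxy group, would keep the number of compound 1. They also leave open whether the longer chain of compound 2 would give a measurable value without the anilino group.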